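Moving a Fluorine on the Difluorophenyl Ring

The source may report more compounds than this note shows. Statements on the series, on what has been measured and on what is new or still open speak of the compounds shown alone.

Compound 2 `CCN(CC)CCCn1c(=O)c(=Cc2ccc(F)c(F)c2)s/c1=C1\C(=O)Nc2cc(F)ccc21` gives 28 nM in a functional assay on HT-29 cells (Homo sapiens) for inhibition, read by MTT assay, with a stated time of 72 h; on this read-out higher numbers stand for weaker inhibition and lower numbers for stronger inhibition.
Compound 3 `CN(C)CCn1c(=O)c(=Cc2ccc(C=O)c(C=O)c2)s/c1=C1\C(=O)Nc2cc(F)ccc21` gives 1360 nM in this assay.
Compound 1 `CCN(CC)CCCn1c(=O)c(=Cc2cc(OC)c(OC)c(OC)c2)s/c1=C1\C(=O)Nc2ccc(C)cc21` is reported in this assay only as a limit, > 200000 nM.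

In this assay compound 2 has the lowest of the two numbers, and compound 3 stands far higher, a gap beyond the scatter. The unmeasured compound 4 `CCN(CC)CCCn1c(=O)c(=Cc2ccc(F)cc2F)s/c1=C1\C(=O)Nc2cc(F)ccc21` keeps every atom of compound 2 but joins them differently: 2,4-difluorophenyl in place of 3,4-difluorophenyl on a double-bonded chain carbon bound to an aromatic carbon. For the measured compounds named here, no measured pair here shows a change of this kind, so the expectation leans on the shared difluorophenyl ring and on the strong inhibition of compound 2 at 28 nM. A step of modest size, in either direction, is expected. Compound 4 is estimated at 45 nM, most likely between 10 nM and 200 nM. The expected step is a 1.6-fold higher number from compound 2 to compound 4 (0.21 log units; within the scatter).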

Compound 4, half-maximal inhibitory concentration: 1520 nM
Compound 4: middle estimate off by 34-fold (1.53 log units), on the low side, outside the stated range (above it).
By their numbers in this assay, from the lowest: compound 2; then compounds 3 and 4 (each within the scatter of the next). At a limit, above all of these: compound 1.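

Moving one fluorine, with no atom gained or lost, matters greatly at this place: with 2,4-difluorophenyl in place of 3,4-difluorophenyl, this assay shows a 54-fold higher number from compound 2 to compound 4 (1.73 log units; beyond the scatter). Having two fluorines on the ring is therefore not enough to keep the low number of compound 2, since their arrangement also counts. Nothing measured here explains this step. The compounds shown leave open whether a plain phenyl ring or a chlorophenyl ring at this place would stay close to compound 2 or land nearer compound 4.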